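Swapping an Amide for a Lactam on the Shared Core

A few compounds are considered here, and "the series" means these few. Any claim that something is new, unique, unknown or untested is made for them only; others in the source may bear on it.

Compound 1 `O=C(Nc1ccccc1)c1cnc(NCc2c(F)ccc3c2CCO3)n2cnnc12` was run in an ADME assay on microsomes from liver (Homo sapiens) for metabolic stability, read by LC-MS, using NADPH, with stated times of 5 min and 30 min, tested at 1 uM (a higher number here means faster removal of the compound, a lower number slower removal), where compound 1 gives 14 mL.min-1.g-1. Among the three numbers in hand this is the lowest. Compound 2 `CNC(=O)c1ccc(-c2cnc(NCc3c(F)ccc4c3CCO4)c3cn[nH]c(=O)c23)c(C)n1` gives 23 mL.min-1.g-1 in this assay, which lies within the scatter of the number for compound 1, so the two cannot be told apart. Compound 3 `Cc1ncccc1-c1cnc(NCc2c(F)ccc3c2CCO3)n2c(=O)[nH]nc12` gives 36 mL.min-1.g-1 in this assay, a number that stands beyond the scatter above compound 1.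

Compound 4 `CC1(C)CC(=O)N(c2cnc(NCc3c(F)ccc4c3CCO4)n3cnnc23)C1` has not yet been measured in this assay. It differs from compound 1 in a single place: 4,4-dimethyl-2-oxopyrrolidin-1-yl in place of phenylcarbamoyl on an aromatic carbon. Going by the values given here, no pair of measured compounds shares this change, so the three numbers give no direct guide to its size. The group that leaves and the group that enters are close in the count of heavy atoms, and the change removes the one hydrogen-bond donor while keeping one acceptor.

The expected step in this assay is a 1.1-fold higher number from compound 1 to compound 4 (0.06 log units; within the scatter), small and not clearly beyond the scatter in either direction. Compound 4 is therefore expected to give 16 mL.min-1.g-1 in this assay, with a range from 7 mL.min-1.g-1 to 40 mL.min-1.g-1.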

Compound 4, intrinsic clearance in microsomes: 16 mL.min-1.g-1
Compound 4: the middle estimate sits on the measured number at the digits printed; low and high end bracket the measured number.
By their numbers in this assay, from the lowest: compounds 1, 4, 2 and 3 (each within the scatter of the next, the first and the last beyond it).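

In this assay, placing 4,4-dimethyl-2-oxopyrrolidin-1-yl in place of phenylcarbamoyl on the aromatic carbon gives a 1.1-fold higher number from compound 1 to compound 4 (0.06 log units; within the scatter), the first step read at this position on the shared core. The two numbers cannot be told apart, so this position accepts the loss of the six-membered aromatic ring of carbon only and of the hydrogen-bond donor, with a five-membered non-aromatic ring entering, and shows no step beyond the scatter in this measure of removal. No measurement at hand explains this outcome, which stands as an observation on this one pair of compounds.

This single pair does not separate the contributions of the ring, the carbonyl and the two methyl groups, and a pyrrolidin-2-one without the methyl groups, a morpholine or a primary carboxamide at the same place would test these parts one at a time. Compound 2 and compound 3 differ from compound 1 in more than one place, so they leave open whether the same tolerance would hold for this change on any other core.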